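Mirror image of compound 3 in the glycine transporter series

This account rests on a few compounds, and the source may have more. Where it says the series, first, only, none or still open, it means among the compounds named here.

Among the compounds with values here, compound 3 `COc1ccc(Sc2ccccc2N2C[C@H](C)N(CC(=O)O)C[C@@H]2C)cc1` stands second highest of the three numbers so far in an assay for inhibition of sodium- and chloride-dependent glycine transporter 1 (Homo sapiens) (on this read-out higher numbers stand for weaker inhibition and lower numbers for stronger inhibition), at 18000 nM; compound 2 `COc1ccc(Sc2ccccc2N2C[C@H](C)N(CC(=O)O)C[C@H]2C)cc1` gives 53000 nM and compound 1 `COc1ccc(Sc2ccccc2N2CC(C)N(CC(=O)O)CC2C)cc1` gives 580 nM. The step from compound 3 to compound 4 `COc1ccc(Sc2ccccc2N2C[C@@H](C)N(CC(=O)O)C[C@H]2C)cc1` is the two compounds have the same atoms and bonds and differ only in configuration as drawn: 2 of 2 stereo elements differ (all stereocentres are inverted: mirror images); a stereocentre at a saturated ring carbon is drawn S in compound 3 and R in compound 4; a stereocentre at a saturated ring carbon is drawn S in compound 3 and R in compound 4. Within the data shown here, the only measured step between fully configured compounds, a 2.9-fold lower number from compound 2 to compound 3 (0.47 log units; beyond the scatter), bears on it directly and was modest. The larger steps, a 91-fold higher number from compound 1 to compound 2 (1.96 log units; beyond the scatter) and a 31-fold higher number from compound 1 to compound 3 (1.49 log units; beyond the scatter), bear on it because the fact that one of compounds 1 and 2 is drawn with a defined configuration and the other without, at the place where they differ and the fact that one of compounds 1 and 3 is drawn with a defined configuration and the other without, at the place where they differ show compound 1 carries no drawn configuration, so its number may reflect a mixture of which compound 4 is the part not yet measured. Since both configured compounds 2 and 3 lie far above compound 1, the strong number of compound 1 is expected to belong largely to compound 4. A large downward step a 72-fold lower number from compound 3 to compound 4 (1.86 log units; beyond the scatter) in this assay is therefore expected. Compound 4 is estimated at 250 nM, with a range from 80 nM to 1500 nM.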

Compound 4, half-maximal inhibitory concentration: 16000 nM
For compound 4 the middle estimate is 64-fold (1.81 log units) below the measured one; the whole stated range lies below it.
By their numbers in this assay, from the lowest: compound 1; then compounds 4 and 3 (each within the scatter of the next); then compound 2.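

In this assay, within the data shown here, inverting both stereocentres together gives a 1.1-fold lower number from compound 3 to compound 4 (0.05 log units; within the scatter), so this mirror-image pair cannot be told apart on this read-out, which the earlier compounds could not show. Inverting a single stereocentre gives a 3.3-fold lower number from compound 2 to compound 4 (0.52 log units; beyond the scatter), a second modest step alongside a 2.9-fold lower number from compound 2 to compound 3 (0.47 log units; beyond the scatter), so among the fully configured compounds every step stays small or modest. The large gap to the undrawn compound 1 now recurs as a 28-fold higher number from compound 1 to compound 4 (1.44 log units; beyond the scatter), so compound 4 does not account for the number of compound 1 any more than compounds 2 and 3 do, and the link between them is only this: the fact that one of compounds 1 and 4 is drawn with a defined configuration and the other without, at the place where they differ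

From the compounds shown here alone, whether the number of compound 1 belongs to the mirror image of compound 2, or to something else in that undrawn sample, stays open. Also open, going by these compounds, is how ethyl groups in place of the two methyl groups on the shared core would read in this assay, in any configuration.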